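Bromo for Fluoro in a Small Cytotoxicity Series

The compounds below may be only part of what the source reports. "The series", "measured", "known", "first", "only" and "open" are said of these compounds alone.

Three compounds were tested in an ADME assay on MT4 cells (Homo sapiens) for cytotoxicity, read by MTT assay; on this read-out lower numbers stand for higher toxicity in this test and higher numbers for lower toxicity in this test. Compound 1 `O=C(CSc1nccn1-c1cccc2ccccc12)Nc1ccccc1Br` gives 30500 nM there, compound 2 `O=C(CSc1nccn1-c1cccc2ccccc12)Nc1ccccc1F` gives 34700 nM, and compound 3 `Cc1ccc(-n2ccnc2SCC(=O)Nc2ccccc2F)cc1` gives 37900 nM; all three numbers lie within the scatter of one another. Compound 1 arises from compound 2 by bromo in place of fluoro on an aromatic carbon, a change that brought a 1.1-fold lower number from compound 2 to compound 1 (0.06 log units; within the scatter). Compound 4 `Cc1ccc(-n2ccnc2SCC(=O)Nc2ccccc2Br)cc1` is the unmeasured partner of compound 3 and differs from it by the same change, (bromo in place of fluoro on an aromatic carbon). How the core of compound 3 differs from that of compound 2 is not broken down here. Because a 1.1-fold lower number from compound 2 to compound 1 (0.06 log units; within the scatter) stayed within the scatter, the estimated step here is a 1.1-fold lower number from compound 3 to compound 4 (0.03 log units; within the scatter). Compound 4 is therefore expected to give about 35000 nM in this assay, most likely falling between 18000 nM and 70000 nM.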

Compound 4, half-maximal cytotoxic concentration: 39300 nM
Compound 4: the middle estimate sits 1.1-fold (0.05 log units) below what was measured; measured number inside the range.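

In this assay bromo in place of fluoro gave a 1.0-fold higher number from compound 3 to compound 4 (0.02 log units; within the scatter) on the second core, so this step, like the earlier one, is too small to count as a real change. Side by side, the two steps agree: the same change on two cores in this assay, a 1.1-fold lower number (0.06 log units; within the scatter) from compound 2 to compound 1 and a 1.0-fold higher number (0.02 log units; within the scatter) from compound 3 to compound 4, 1.2-fold (0.07 log units) apart, within the scatter of two such steps.

This shows that the swap left the number within the scatter on both cores, but neither step is large enough to show how a clear effect would carry from one core to the other.

The compounds shown leave open whether an amine or a carboxylic acid at the same spot on the ring would give a step beyond the scatter. They also leave open whether bromo for fluoro would stay as quiet on any further core.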